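A few compounds are considered here, and "the series" means these few. Any claim that something is new, unique, unknown or untested is made for them only; others in the source may bear on it.

Compound 1 `O=C(CCC1=CCN(CCCc2ccc(Br)cc2)C1=O)NO` and compound 2 `O=C(CCC1=CCN(Cc2ccc(F)cc2)C1=O)NO` share a core and differ in the side arm attached to it. In a functional assay on NUGC-3 cells (Homo sapiens) for inhibition, read by sulforhodamine B assay (a lower number here means a stronger inhibitor of growth, a higher number a weaker inhibitor of growth), compound 1 gives 2200 nM, while compound 2 gives 6060 nM, the higher of the two numbers and so the weaker growth inhibitor. Compound 3 `N#Cc1ccc(CN2CC=C(CCC(=O)NO)C2=O)cc1` has not yet been tested; it differs from compound 2 by cyano in place of fluoro on an aromatic carbon. Among the measured compounds shown here, no measured pair shows a change of this kind, so the step of a 1.2-fold lower number from compound 2 to compound 3 (0.08 log units; within the scatter) is expected to be small and within the usual scatter. Compound 3 is therefore estimated to give 5000 nM in this assay, with a range from 2000 nM to 14000 nM.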

Compound 3, concentration for 50% growth inhibition in the NUGC-3 assay: > 10000 nM
Compound 3 was reported as a limit; the forecaster's own chance of this, stated with the estimate: 5%; at least 2.0-fold (0.30 log units) between middle value and limit.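

In the NUGC-3 assay compound 3 is reported only as a limit, > 10000 nM. Among the compounds shown here, this is the first reading of a change at this place on the aromatic ring, para to a large group: cyano in place of fluoro gives an at least 1.6-fold higher number from compound 2 to compound 3 (0.21 log units; that floor lies within the scatter), so growth inhibition shows no gain, and only a floor is known for the step. In a physicochemical assay for lipophilicity (on this read-out higher numbers stand for higher lipophilicity and lower numbers for lower lipophilicity), compound 2 gives 0.571 and compound 3 gives 0.197. The same change comes with lower lipophilicity in the physicochemical assay: the measured distribution coefficient of compound 2, 0.571, and of compound 3, 0.197, a number 0.37 log units lower (beyond the scatter)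

This single pair cannot tell whether the lipophilicity change is tied to the growth result. On these data alone, how an amine or a methoxy group at this place would read in the NUGC-3 assay also remains open.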